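Chloro for Fluoro on the Pendant Phenyl Ring

The source may report more compounds than this note shows. Statements on the series, on what has been measured and on what is new or still open speak of the compounds shown alone.

Compound 2 `Fc1ccc(-c2cn3ccnc3c(-c3ccc4ncn(C5CCCCC5)c4c3)n2)cc1` holds the lower of the two measured numbers in a functional assay on OVCAR-4 cells (Homo sapiens) for inhibition, read by sulforhodamine B assay, with a stated time of 48 h, tested at 10 uM (on this read-out lower numbers stand for less inhibition and higher numbers for more inhibition at the one concentration tested (going by the name of the read-out)), where compound 2 gives 5.73%. Within the data shown here, its nearest neighbour, compound 1 `c1ccc2c(-c3cn4ccnc4c(-c4ccc5ncn(C6CCCCC6)c5c4)n3)cccc2c1`, gives 19.7% in this assay; the only measured step, a number 14 percentage points lower from compound 1 to compound 2 (beyond the scatter), came with 4-fluorophenyl in place of naphthalen-1-yl on an aromatic carbon. Compound 3 `Clc1ccc(-c2cn3ccnc3c(-c3ccc4ncn(C5CCCCC5)c4c3)n2)cc1` differs from compound 2 by chloro in place of fluoro on an aromatic carbon. Among the measured compounds shown here, no measured step covers a change of one halogen for another, so the single step from compound 1 to compound 2, which exchanges a whole ring system, bears only loosely on it and gives no direction. For compound 3 the expected step is a number 2.3 percentage points higher from compound 2 to compound 3 (within the scatter), none beyond the scatter. Compound 3 is estimated at 8% in this assay, within a range from 0% to 25%.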

Compound 3, a percentage reported as inhibition, at one concentration (the size of the read-out at that concentration, not a potency): 4.57%
Beside the measured number, compound 3's estimate is 3.4 percentage points above it; the range from low to high includes it.
By their numbers in this assay, from the lowest: compounds 3 and 2 (each within the scatter of the next); then compound 1.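

In this assay, among these compounds, this is the first step that keeps the phenyl ring and changes only the halogen on the aromatic carbon para to a large group, and a number 1.2 percentage points lower from compound 2 to compound 3 (within the scatter) does not separate 4-fluorophenyl from 4-chlorophenyl. The replacement of naphthalen-1-yl now has a second case, a number 15.1 percentage points lower from compound 1 to compound 3 (beyond the scatter) in the same direction as a number 14 percentage points lower from compound 1 to compound 2 (beyond the scatter) and likewise beyond the scatter, so neither halogenated phenyl compound reaches the number of compound 1. Nothing measured here accounts for these numbers.

From the compounds shown here alone, whether a different kind of group in this place, such as an amine, a carboxylic acid or a longer chain, would move the number away from that of compound 2 and compound 3 stays open. Also open, going by these compounds, is what plain hydrogen there would give.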